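Ring amine in place of methyl on the acyl chain

The source may report more compounds than this note shows. Statements on the series, on what has been measured and on what is new or still open speak of the compounds shown alone.

Measured so far in a functional assay on PC-3 cells (Homo sapiens) for cytotoxicity, read by MTT assay, with a stated time of 48 h; a lower number here means a stronger inhibitor, a higher number a weaker inhibitor:
compound 1 `CC1=NN(C(=O)COc2ccc(Cl)cc2)C(c2ccccc2O)C1` — 38800 nM
compound 2 `CC1=NN(C(=O)CN2CCCC2)C(c2ccccc2O)C1` — 6670 nM
compound 3 `CCC(=O)N1N=C(c2cc3ccccc3oc2=O)CC1c1ccccc1` — 4370 nM

Compound 3 stands apart from compound 1, the gap between them lying beyond the usual scatter, while its number and that of compound 2 sit within the scatter of each other, so no order between compound 3 and compound 2 can be read from these values.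

The unmeasured compound 4 `NC(=O)C1CCN(CC(=O)N2N=C(c3cc4ccccc4oc3=O)CC2c2ccccc2)CC1` differs from compound 3 by 4-carbamoylpiperidin-1-yl in place of methyl on a saturated chain carbon bound to a carbonyl carbon. Within the data shown here, the one measured step that bears on this change is a 5.8-fold lower number from compound 1 to compound 2 (0.76 log units; beyond the scatter), where a cyclic amine entered on a saturated chain carbon bound to a carbonyl carbon. That step, however, replaced 4-chlorophenoxy rather than methyl, so it speaks to the present change only loosely. On that basis a modest step toward a lower number is expected for compound 4, of the size a 1.7-fold lower number from compound 3 to compound 4 (0.24 log units; within the scatter). Compound 4 is therefore estimated at 2500 nM, within a range from 800 nM to 8000 nM.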

Compound 4, half-maximal inhibitory concentration: 8310 nM
For compound 4 the middle estimate is 3.3-fold (0.52 log units) below the measured one; measured number outside the range, above it.
By their numbers in this assay, from the lowest: compounds 3, 2 and 4 (each within the scatter of the next); then compound 1.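

In this assay, putting 4-carbamoylpiperidin-1-yl in place of methyl on a saturated chain carbon bound to a carbonyl carbon gives a 1.9-fold higher number from compound 3 to compound 4 (0.28 log units; within the scatter) and so no readable change: on this core the position carries a much larger group, with a six-membered ring and a hydrogen-bond donor, without a shift beyond the scatter. The earlier step of a 5.8-fold lower number from compound 1 to compound 2 (0.76 log units; beyond the scatter) therefore does not show that a cyclic amine at this place always brings a lower number, since compound 4 goes against that reading. No measurement shown here accounts for this result.

The compounds shown leave open whether the ring or its carbamoyl decides the outcome, which an unsubstituted piperidin-1-yl or a carboxylic acid in place of the carbamoyl would help to separate. They also leave open whether pyrrolidin-1-yl behaves on this core as it does on the core of compound 2.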